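The source may report more compounds than this note shows. Statements on the series, on what has been measured and on what is new or still open speak of the compounds shown alone.

In a functional assay on NCI-H1975 cells (Homo sapiens) for antiproliferative activity (a higher number here means a weaker inhibitor, a lower number a stronger inhibitor), compound 1 `Cc1c2c(n3c1CCCN[C@@H](C)[C@H](C)Nc1cc-3ccc1C(N)=O)CC(C)(C)CC2=O` gives 20 nM. Going by the values given here, compound 2 `Cc1c2c(n3c1CCCN(C(=O)CN)[C@@H](C)[C@H](C)Nc1cc-3ccc1C(N)=O)CC(C)(C)CC2=O`, with an (aminomethyl)carbonyl in place of hydrogen on an amine nitrogen in a ring, gives 380 nM, the higher of the only two numbers so far. Among the compounds with values here, the single measured step, a 19-fold higher number from compound 1 to compound 2 (1.28 log units; beyond the scatter), is large and beyond the scatter.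

Compound 3 `COCCC(=O)N1CCCc2c(C)c3c(n2-c2ccc(C(N)=O)c(c2)N[C@@H](C)[C@@H]1C)CC(C)(C)CC3=O` differs from compound 2 in one place: methoxymethyl in place of amino on a saturated chain carbon bound to a carbonyl carbon. That is methoxymethyl in place of amino on a saturated chain carbon bound to a carbonyl carbon. Within the data shown here, the carbonyl on the ring nitrogen stays, so the measured step that added it is the closest guide, though no measured step covers this swap itself. The number in this assay is therefore expected to stay near that of compound 2, with no change beyond the scatter and no firm direction.

The expected change is a 1.3-fold lower number from compound 2 to compound 3 (0.10 log units; within the scatter). For compound 3 the estimated value is 300 nM, with an expected range of 90 nM to 1000 nM.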

Compound 3, half-maximal inhibitory concentration: 37 nM
Estimate against measurement, compound 3: 8.1-fold (0.91 log units) above; the whole stated range lies above it.
By their numbers in this assay, from the lowest: compounds 1 and 3 (each within the scatter of the next); then compound 2.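

In this assay, a carbonyl on the amine nitrogen in the ring does not by itself go with a weaker number. With (2-methoxyethyl)carbonyl there, a 1.9-fold higher number from compound 1 to compound 3 (0.27 log units; within the scatter) stays within the scatter, unlike the large 19-fold higher number from compound 1 to compound 2 (1.28 log units; beyond the scatter) seen with (aminomethyl)carbonyl. What the carbonyl carries therefore matters a great deal at this position, as a 10-fold lower number from compound 2 to compound 3 (1.01 log units; beyond the scatter) shows for the swap of amino for methoxymethyl, and nothing available explains why the two groups differ so sharply.

This swap changes both the end group and the chain length, so the two effects cannot yet be told apart. A 2-aminoethyl group on the same carbonyl would test the amine on a longer chain, and a methoxymethyl group would test the ether on a shorter one.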